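The compounds below may be only part of what the source reports. "The series", "measured", "known", "first", "only" and "open" are said of these compounds alone.

Compound 1, `O=C(O)[C@@H]1NC[C@@H](O)[C@H](O)[C@@H]1O`, is one of three stereoisomers of a single small ring bearing a carboxylic acid, a ring nitrogen and three hydroxyl groups. Among the measured compounds shown here, in an assay for inhibition of alpha-N-acetylgalactosaminidase (Gallus gallus), tested at 1000 uM (a higher number here means more inhibition at the concentration tested (going by the name of the read-out), a lower number less inhibition), compound 1 gives 10%, the second highest of the three numbers measured so far. Compound 2, `O=C(O)[C@H]1NC[C@@H](O)[C@H](O)[C@@H]1O`, gives 11% in this assay, and compound 3, `O=C(O)[C@@H]1NC[C@H](O)[C@H](O)[C@H]1O`, gives 4.4%. The steps between them are all small: a number 1 percentage points higher from compound 1 to compound 2 (within the scatter), a number 5.6 percentage points lower from compound 1 to compound 3 (within the scatter) and a number 6.6 percentage points lower from compound 2 to compound 3 (within the scatter). Each pair differs only in the drawn configuration of ring carbons the fact that compounds 1 and 2 differ only in the configuration as drawn the fact that compounds 1 and 3 differ only in the configuration as drawn (the fact that compounds 2 and 3 differ only in the configuration as drawn), so these three steps show that swapping one, two or three stereocentres within this set has so far left the read-out inside the scatter.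

Compound 4, `O=C(O)[C@@H]1NC[C@H](O)[C@@H](O)[C@H]1O`, is the fourth stereoisomer. Compared with compound 1 the change is the two compounds have the same atoms and bonds and differ only in configuration as drawn: 3 of 4 stereo elements differ; a stereocentre at a saturated ring carbon is drawn R in compound 1 and S in compound 4; a stereocentre at a saturated ring carbon is drawn S in compound 1 and R in compound 4; a stereocentre at a saturated ring carbon is drawn R in compound 1 and S in compound 4. All three measured steps bear on it, since each is also a change of configuration alone, and none of them moved the number beyond the scatter. The step from compound 1 is therefore expected to be a number 2 percentage points lower from compound 1 to compound 4 (within the scatter), with no direction to it beyond the scatter. Compound 4 is estimated to give 8% in this assay, within a range from 0% to 20%.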

Compound 4, a percentage reported as inhibition, at one concentration (the size of the read-out at that concentration, not a potency): 4%
Estimate against measurement, compound 4: 4 percentage points above, within the range that was stated.
By their numbers in this assay, from the lowest: compounds 4, 3, 1 and 2 (each within the scatter of the next).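

With compound 4 in place, the set includes a pair of mirror images, and even inverting all four stereocentres gives only a number 7 percentage points lower from compound 2 to compound 4 (within the scatter), which is a full reversal of configuration that still leaves the read-out inside the scatter: the fact that compounds 2 and 4 differ only in the configuration as drawn. The smallest possible change, a single inverted stereocentre, gives a number 0.4 percentage points lower from compound 3 to compound 4 (within the scatter), and inverting three stereocentres gives a number 6 percentage points lower from compound 1 to compound 4 (within the scatter). Taken together, one, three and four inversions now join the earlier steps, and no arrangement of the hydroxyl groups and the carboxylic acid among these four compounds stands apart from the others in this assay.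

As far as these compounds go, all four compounds carry the same atoms and bonds, so it remains open what a hydroxymethyl group in place of the carboxylic acid, or a butyl chain on the ring nitrogen, would do to the read-out. From the compounds shown here alone, a number at one concentration is also not a potency, so whether these stereoisomers would separate under a different kind of measurement remains open too.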